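Little movement expected from compound 3 to compound 4

The compounds below may be only part of what the source reports. "The series", "measured", "known", "first", "only" and "open" are said of these compounds alone.

Compound 3 (`CCOC(=O)C1=C(N/N=C(\C#N)C(N)=O)Nc2[nH]nc(C)c2C1c1ccc(N(C)C)cc1`) gives 48400 nM in a functional assay on HepG2 cells (Homo sapiens) for inhibition, read by MTT assay, with a stated time of 48 h (on this read-out lower numbers stand for stronger inhibition and higher numbers for weaker inhibition), and so stands level, within the scatter, with compound 1 (`CCOC(=O)C1=C(N/N=C(/C#N)C(=O)OCC)Nc2[nH]nc(C)c2C1c1ccc(N(C)C)cc1`) at 46400 nM and compound 2 (`CCOC(=O)C1=C(N/C=N/c2nnc(S(N)(=O)=O)s2)Nc2[nH]nc(C)c2C1c1ccc(N(C)C)cc1`) at 38100 nM on this read-out. The change to compound 4 (`CCOC(=O)C1=C(NN=C(C#N)C#N)Nc2[nH]nc(C)c2C1c1ccc(N(C)C)cc1`) is a group of 6 heavy atoms (3 carbon, 3 nitrogen; no ring) in place of a group of 7 heavy atoms (3 carbon, 3 nitrogen, 1 oxygen; no ring), on an amine nitrogen on an amine nitrogen whose other neighbours are a double-bonded ring carbon. The measured steps that bear on it change the group on that same nitrogen. They are a 1.0-fold higher number from compound 1 to compound 3 (0.02 log units; within the scatter) and a 1.3-fold higher number from compound 2 to compound 3 (0.10 log units; within the scatter) and also a 1.2-fold lower number from compound 1 to compound 2 (0.09 log units; within the scatter) and all three lie within the scatter, even where a group with one five-membered aromatic ring enters. Among the measured compounds shown here, no measured compound carries the new group, so this evidence is thin. The expected outcome is a 1.1-fold lower number from compound 3 to compound 4 (0.03 log units; within the scatter) in this assay with no step beyond the scatter and no clear direction. Compound 4 is estimated at 45000 nM with an expected range from 22000 nM to 90000 nM on this read-out.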

Compound 4, half-maximal inhibitory concentration: 13700 nM
Beside the measured number, compound 4's estimate is 3.3-fold (0.52 log units) above it; measured number below the stated range.
By their numbers in this assay, from the lowest: compound 4; then compounds 2, 1 and 3 (each within the scatter of the next).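

In this assay the group on the amine nitrogen whose other neighbours are a double-bonded ring carbon can shift the number beyond the scatter, which no earlier change there had done: the data show a 3.5-fold lower number from compound 3 to compound 4 (0.55 log units; beyond the scatter) and a 3.4-fold lower number from compound 1 to compound 4 (0.53 log units; beyond the scatter) and a 2.8-fold lower number from compound 2 to compound 4 (0.44 log units; beyond the scatter) as modest steps. Compound 4 therefore stands lowest of the four, with 0 hydrogen-bond donors and 2 triple bonds in the entering group against 1 hydrogen-bond donor and 1 triple bond in the group that leaves compound 3. Nothing shown here accounts for the step.

The compounds shown leave open whether the lower number requires both nitrile groups, or whether a carboxylic acid or a trifluoromethyl in place of one nitrile would keep it. They also leave open whether the step carries over to other substituents on the shared core.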